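The source may report more compounds than this note shows. Statements on the series, on what has been measured and on what is new or still open speak of the compounds shown alone.

Measured in a functional assay on HCT-116 cells (Homo sapiens) for inhibition, read by colorimetric assay, with a stated time of 3 days; a lower number here means a stronger inhibitor, a higher number a weaker inhibitor:
- compound 1 `O=C(CCCCCCNC(=O)C(O)(O)C(F)(F)F)Nc1ccncc1`: 6670 nM
- compound 2 `O=C(CCCCCCNC(=O)C(O)(O)C(F)(F)F)Nc1ccccc1`: 9140 nM
- compound 3 `O=C(CCCCCCNC(=O)C(O)(O)C(F)(F)F)Nc1nc2ccccc2s1`: 2370 nM

Compound 3 has the lowest number of the three, and its steps to both others lie beyond the scatter. Compound 1 and compound 2 do not separate, with a 1.4-fold higher number from compound 1 to compound 2 (0.14 log units; within the scatter) within the scatter.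

The next compound is compound 4 `O=C(CCCCCCNC(=O)C(O)(O)C(F)(F)F)Nc1nccs1`, with 1,3-thiazol-2-yl in place of 1,3-benzothiazol-2-yl on an amide-type nitrogen. The five-membered aromatic ring with 2 hetero atoms stays, and the six-membered aromatic ring of carbon only goes.

Going by the values given here, no measured step makes this exact change. The nearest evidence is a 2.8-fold lower number from compound 1 to compound 3 (0.45 log units; beyond the scatter) and a 3.9-fold lower number from compound 2 to compound 3 (0.59 log units; beyond the scatter), both modest, since compound 1 and compound 2 also lack the 1,3-benzothiazol-2-yl group. Leaving that group is therefore expected to give a modest rise in this assay, though 1,3-thiazol-2-yl itself remains untested. The expected step is a 2.1-fold higher number from compound 3 to compound 4 (0.32 log units; beyond the scatter). The estimate for compound 4 is 5000 nM, with an expected range of 2200 nM to 11000 nM.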

Compound 4, half-maximal inhibitory concentration: 10800 nM
The estimate for compound 4 lay 2.2-fold (0.33 log units) below the measured number, within the range that was stated.
By their numbers in this assay, from the lowest: compound 3; then compounds 1, 2 and 4 (each within the scatter of the next).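

In this assay, the loss of the six-membered aromatic ring of carbon only gives a 4.6-fold higher number from compound 3 to compound 4 (0.66 log units; beyond the scatter) and so removes the separation that compound 3 held over the other compounds at this position on the amide-type nitrogen. Going by these compounds alone, the five-membered aromatic ring with 2 hetero atoms does not keep that separation on its own: a 1.2-fold higher number from compound 2 to compound 4 (0.07 log units; within the scatter) and a 1.6-fold higher number from compound 1 to compound 4 (0.21 log units; within the scatter) place 1,3-thiazol-2-yl level with phenyl and pyridin-4-yl, leaving 1,3-benzothiazol-2-yl as the only group of the four that stands apart. No measurement shown here accounts for this difference.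

Open, on these data alone, is whether a naphthalen-2-yl group, with two fused rings of carbon only, would match 1,3-benzothiazol-2-yl. Also open, as far as these compounds go, is whether a methoxy group on 1,3-benzothiazol-2-yl or a longer chain would shift the number in this assay further.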